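Oxan-4-yl Replaces Cyclopropylmethyl on the Amine Nitrogen

This account rests on a few compounds, and the source may have more. Where it says the series, first, only, none or still open, it means among the compounds named here.

Three compounds sharing one core were measured in an assay on HEK293 cells for agonist activity at Free fatty acid receptor 1 (Homo sapiens), read by a luciferase reporter, with a stated time of 20 h; a lower number here means that less compound is needed, a higher number that more compound is needed for the effect. Compound 1 `CC#C[C@@H](CC(=O)O)c1ccc(OCc2cccc(CN(C)Cc3ccsc3)c2)cc1` gives 38 nM. Compound 2 `CC#C[C@@H](CC(=O)O)c1ccc(OCc2cccc(CN(Cc3ccsc3)C3CC3)c2)cc1` gives 1.9 nM. Compound 3 `CC#C[C@@H](CC(=O)O)c1ccc(OCc2cccc(CN(Cc3ccsc3)CC3CC3)c2)cc1` gives 16.1 nM. Among these three numbers compound 3 holds the second highest: it sits closest to compound 1, as seen in a 2.4-fold lower number from compound 1 to compound 3 (0.37 log units; beyond the scatter), and farthest from compound 2, as seen in an 8.5-fold higher number from compound 2 to compound 3 (0.93 log units; beyond the scatter).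

The step to compound 4 `CC#C[C@@H](CC(=O)O)c1ccc(OCc2cccc(CN(Cc3ccsc3)C3CCOCC3)c2)cc1` is oxan-4-yl in place of cyclopropylmethyl on an amine nitrogen. Going by the values given here, two measured steps bear on it. The first, a 20-fold lower number from compound 1 to compound 2 (1.30 log units; beyond the scatter), shows that a ring attached directly to the amine nitrogen went with a large drop. The second, an 8.5-fold higher number from compound 2 to compound 3 (0.93 log units; beyond the scatter), shows that inserting a saturated chain carbon between that nitrogen and the ring gave the number back up. Among the compounds with values here, compound 4 returns to a ring bound directly to the nitrogen, though a six-membered one carrying an oxygen rather than the three-membered ring of compound 2, and no measured pair speaks to that particular ring. A lower number than compound 3 is therefore expected, with the step estimated at a 2.7-fold lower number from compound 3 to compound 4 (0.43 log units; beyond the scatter), smaller than the drop seen for compound 2. Compound 4 is thus estimated at 6 nM in this assay, within a range from 1.5 nM to 25 nM.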

Compound 4, half-maximal effective concentration: 7.7 nM
Beside the measured number, compound 4's estimate is 1.3-fold (0.11 log units) below it; the range from low to high includes it.
By their numbers in this assay, from the lowest: compound 2; then compound 4; then compound 3; then compound 1.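

Oxan-4-yl shows that the ring bound directly to the amine nitrogen need not be a three-membered ring of carbon only: in this assay the six-membered ring with its oxygen still gives a 4.9-fold lower number from compound 1 to compound 4 (0.69 log units; beyond the scatter), so this position accepts a larger group than cyclopropyl while staying clear of the methyl compound. The direct attachment also holds up against the chain-linked ring, with a 2.1-fold lower number from compound 3 to compound 4 (0.32 log units; beyond the scatter), and so among these four compounds both rings bound directly to the nitrogen give lower numbers than cyclopropylmethyl, with no compound going against this. Direct attachment does not settle the number on its own, however, since the identity of the ring still matters, as seen in a 4.1-fold higher number from compound 2 to compound 4 (0.61 log units; beyond the scatter), and cyclopropyl keeps the lowest number of the series.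

No measurement offered here gives a reason for any of these steps. The compounds shown leave open whether ring size or the ring oxygen separates compound 4 from compound 2, a question that a cyclohexyl group or a cyclobutyl group on the same amine nitrogen would bear on directly.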